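A few compounds are considered here, and "the series" means these few. Any claim that something is new, unique, unknown or untested is made for them only; others in the source may bear on it.

Working notes on the series.

Of the compounds shown here, three have been measured in a functional assay on the whole organism (strain Wistar) for inhibition, with Rattus norvegicus as the target, read by paw edema, with stated times of 60 min and 1 h, at a dose of 100 mg/kg by the oral route; on this read-out higher numbers stand for more inhibition at the one dose given (going by the name of the read-out) and lower numbers for less inhibition. Compound 1 `COc1cc2c(cc1OC)C(CC(=O)O)CC2` gives 18.8%. Compound 2 `CNC(=O)CC1CCc2cc(OC)c(OC)cc21`, which carries methylamino in place of hydroxy on the carbonyl carbon, gives 15.6%; the step of a number 3.2 percentage points lower from compound 1 to compound 2 (within the scatter). Compound 3 `COc1cc2c(cc1OC)C(CC(=O)N1CCNCC1)CC2`, which carries piperazin-1-yl on the same carbonyl carbon, gives 62.5% and stands highest of the three, beyond the scatter from both others: a number 43.7 percentage points higher from compound 1 to compound 3 (beyond the scatter) and a number 46.9 percentage points higher from compound 2 to compound 3 (beyond the scatter).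

Compound 4 `COc1cc2c(cc1OC)C(CC(=O)NCCO)CC2` is not yet measured in this assay. It differs from compound 3 as follows: (2-hydroxyethyl)amino in place of piperazin-1-yl on a carbonyl carbon. Among the measured compounds shown here, of the measured steps, the one from compound 2 to compound 3 bears most directly, since compound 2 and compound 4 both carry a substituted amino group on the carbonyl carbon while compound 3 alone carries the ring; that step was large and upward. The step from compound 1 to compound 2 shows that exchanging hydroxy for methylamino changed nothing beyond the scatter. Both rings of evidence point to the ring of compound 3 being the feature that sets it apart. A large downward step is therefore expected from compound 3 to compound 4, estimated at a number 34.5 percentage points lower from compound 3 to compound 4 (beyond the scatter), and compound 4 is expected to give about 28%, within a range of 10% to 50%.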

Compound 4, a percentage reported as inhibition, in the whole organism at one dose (the size of the read-out at that dose, not a potency): 0%
Estimate against measurement, compound 4: 28 percentage points above; the whole stated range lies above it.
By their numbers in this assay, from the lowest: compound 4; then compounds 2 and 1 (each within the scatter of the next); then compound 3.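

In this assay, the carbonyl carbon now shows a downward move as well as an upward one: (2-hydroxyethyl)amino in place of piperazin-1-yl gives a number 62.5 percentage points lower from compound 3 to compound 4 (beyond the scatter), which removes the whole of the read-out seen with the ring. An open-chain amide is also not interchangeable with methylamino here, since hydroxymethyl in place of hydrogen on the saturated chain carbon bound to the amide-type nitrogen gives a number 15.6 percentage points lower from compound 2 to compound 4 (beyond the scatter), and (2-hydroxyethyl)amino in place of hydroxy gives a number 18.8 percentage points lower from compound 1 to compound 4 (beyond the scatter), so this group stands beyond the scatter from both the amide and the acid that had lain within scatter of each other. No measurement at hand bears on the reason for these differences.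

The compounds shown leave open whether the high value of compound 3 rests on the ring itself or on the second nitrogen of piperazin-1-yl, a question that piperidin-1-yl and morpholin-4-yl on the same carbonyl carbon would address. They also leave open whether the hydroxy at the end of the chain in compound 4 matters, which (2-methoxyethyl)amino or ethylamino would test.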